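The source may report more compounds than this note shows. Statements on the series, on what has been measured and on what is new or still open speak of the compounds shown alone.

Notes on the series in a functional assay on OVCAR-4 cells (Homo sapiens) for inhibition, read by sulforhodamine B assay, with a stated time of 48 h; on this read-out lower numbers stand for higher toxicity in this test and higher numbers for lower toxicity in this test. Compound 1 (`O=C(Nc1cccc(-n2cc(-c3ccncc3)c(-c3ccc(Cl)c(O)c3)n2)c1)Nc1cccc(C(F)(F)F)c1`) gives > 32500 nM, which is a limit and not a number. Compound 2 (`COc1cc(-c2nn(-c3cccc(NC(=O)Nc4ccc(Cl)c(Cl)c4)c3)cc2-c2ccncc2)ccc1Cl`) gives > 50000 nM, again a limit. Compound 3 (`O=C(Nc1cccc(-n2cc(-c3ccncc3)c(-c3ccc(Cl)c(O)c3)n2)c1)Nc1ccc(Cl)c(Cl)c1`) gives > 32500 nM, also a limit, so it offers no number as a starting point.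

Compound 4 (`O=C(Nc1cccc(-n2cc(-c3ccncc3)c(-c3ccc(Cl)c(O)c3)n2)c1)Nc1ccc(Cl)c(C(F)(F)F)c1`) carries trifluoromethyl in place of chloro on an aromatic carbon, ortho to a chloro group and meta to a large group: trifluoromethyl in place of chloro on an aromatic carbon.

Two measured changes bear on this one. The closer, 3,4-dichlorophenyl in place of 3-(trifluoromethyl)phenyl on an amide-type nitrogen, is a step that the two limits leave unreadable from compound 1 to compound 3. The other, hydrogen in place of methyl on an oxygen on an aromatic ring, is a step that the two limits leave unreadable from compound 2 to compound 3. Going by the values given here, neither gives a size, and no compound here has yet left the limits of this assay, so no step beyond the usual scatter is expected, in either direction. The expected change is a step that the limit leaves unreadable from compound 3 to compound 4. For compound 4 the estimate is 35000 nM, with an expected range of 15000 nM to 60000 nM.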

Compound 4, concentration lethal to 50% of the cells: > 32500 nM
Compound 4: only a limit was reported (the forecaster's own chance of this, stated with the estimate: 85%); the middle value does not contradict the limit.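

In this assay compound 4 stands at a limit, as compound 1 and compound 3 do, so no step from compound 1 or compound 3 to compound 4 can be read: the limit of > 32500 nM in this assay, at which 3 of the 4 values shown sit.

The compounds shown leave open the size and direction of both changes, trifluoromethyl in place of chloro and chloro in place of hydrogen, on this read-out.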